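Swapping 4-methylphenyl for 3-bromophenyl in compound 3

This account rests on a few compounds, and the source may have more. Where it says the series, first, only, none or still open, it means among the compounds named here.

- compound 1 `COc1ccc2[nH]cc(CCCN3CCN(C(=O)CN4CCN(C(=O)c5ccccc5)CC4)CC3)c2c1` with > 200000 nM (a limit of the assay)
- compound 2 `COc1ccc2[nH]cc(CCCN3CCN(C(=O)CN4CCN(C(=O)c5ccc(C)cc5)CC4)CC3)c2c1` with 147000 nM (a measured number)

Within the data shown here, in an ADME assay on HEK293 cells (Homo sapiens) for cytotoxicity, read by MTT assay, with a stated time of 72 h (a higher number here means a weaker inhibitor, a lower number a stronger inhibitor), compound 2 gives 147000 nM as the only exact number so far. Compound 1 gives > 200000 nM which is a limit of the assay.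

The next structure is compound 3 `COc1ccc2[nH]cc(CCCN3CCN(C(=O)CN4CCN(C(=O)c5cccc(Br)c5)CC4)CC3)c2c1` and its change is 3-bromophenyl in place of 4-methylphenyl on a carbonyl carbon with 3-bromophenyl in place of 4-methylphenyl on a carbonyl carbon. Among the measured compounds shown here, the only measured guide is an at least 1.3-fold lower number from compound 1 to compound 2 (0.13 log units; that floor lies within the scatter) and that step lies within the scatter, so no clear shift is expected. The expected change is a 1.2-fold lower number from compound 2 to compound 3 (0.09 log units; within the scatter) which stays within the scatter. In this assay the estimated value for compound 3 is 120000 nM within an expected range of 55000 nM to 200000 nM as a best guess.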

Compound 3, half-maximal inhibitory concentration: 57000 nM
The estimate for compound 3 lay 2.1-fold (0.32 log units) above the measured number; the measured number falls inside the stated range.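

In this assay, among these compounds, 3-bromophenyl in place of 4-methylphenyl on the carbonyl carbon gives the first step here that is certainly beyond the scatter (a 2.6-fold lower number from compound 2 to compound 3 (0.41 log units; beyond the scatter)). The bromo group alone also clears the scatter (an at least 3.5-fold lower number from compound 1 to compound 3 (0.54 log units; beyond the scatter)), whereas the floor of the methyl step did not. Compound 1 stands only at a limit, so this second step is a floor: (the limit of > 200000 nM in this assay, at which 1 of the 3 values shown sits).

From compound 2 to compound 3, the group and its place on the ring change together, so the two cannot be separated. Going by these compounds, how an amine or a carboxylic acid on this ring would behave stays open.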